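Piperidinylmethyl for butoxy on the carbonyl of compound 2

The source may report more compounds than this note shows. Statements on the series, on what has been measured and on what is new or still open speak of the compounds shown alone.

Compound 1 `CC(C)c1ccc(C2CN(C)Cc3c(N)cccc32)cc1`: about 65 mg/kg
Compound 2 `CCCCOC(=O)Nc1cccc2c1CN(C)CC2c1ccccc1`: 12 mg/kg

In a functional assay on the whole organism for inhibition of sodium-dependent dopamine transporter (Mus musculus) (a higher number here means that more compound is needed for the effect, a lower number that less compound is needed), compound 2 gives 12 mg/kg, the lowest of the two numbers, and compound 1 gives about 65 mg/kg, a gap that lies beyond the scatter. Compound 3 `CN1Cc2c(NC(=O)CN3CCCCC3)cccc2C(c2ccccc2)C1` differs from compound 2 in one place: (piperidin-1-yl)methyl in place of butoxy on a carbonyl carbon. Within the data shown here, no pair of measured compounds traces this change, so the size of the step is not known from the data. The step from compound 2 to compound 3 is expected to be small, a 1.7-fold higher number from compound 2 to compound 3 (0.22 log units; within the scatter), possibly none beyond the scatter. Compound 3 is estimated at 20 mg/kg, with a range from 6 mg/kg to 70 mg/kg.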

Compound 3, dose for half-maximal effect: about 60 mg/kg
Estimate against measurement, compound 3: 3.0-fold (0.48 log units) below, within the range that was stated.
By their numbers in this assay, from the lowest: compound 2; then compounds 3 and 1 (each within the scatter of the next).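

Placing (piperidin-1-yl)methyl instead of butoxy on the carbonyl carbon gives a 5.0-fold higher number from compound 2 to compound 3 (0.70 log units; beyond the scatter) in this assay. This shows that the group on this carbonyl carbon affects the dose needed, which compounds 1 and 2 could not show, as they differ in more than one place. Still open, from the compounds shown here alone, is whether an ethoxy group, a longer alkoxy chain such as hexyloxy, or an open-chain dimethylaminomethyl group on this carbonyl would stand nearer to compound 2 or compound 3. No measurement shown gives a reason for this step.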